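Changing the amide ring of compound 3

A few compounds are considered here, and "the series" means these few. Any claim that something is new, unique, unknown or untested is made for them only; others in the source may bear on it.

In an ADME assay on LLC-MK2 cells (Macaca mulatta) for cytotoxicity, read by spectrophotometry and crystal violet staining, with a stated time of 4 days (a lower number here means that less compound is tolerated, a higher number that more compound is tolerated), compound 1 `CC(C)n1ncc2c(C(=O)Nc3ccc(F)cc3)cc(-c3cccs3)nc21` gives > 200000 nM, which is a limit of the measurement and not a number. Compound 3 `CC(C)n1ncc2c(C(=O)Nc3ccc(F)cn3)cc(-c3cccs3)nc21` gives > 200000 nM, and this too is a limit. Compound 2 `CC(C)n1ncc2c(C(=O)Nc3cccc(C(N)=O)c3)cc(-c3cccs3)nc21` gives a real number, 25000 nM. Compound 4 `CC(C)n1ncc2c(C(=O)Nc3cccc(F)c3F)cc(-c3cccs3)nc21` carries 2,3-difluorophenyl in place of 5-fluoropyridin-2-yl on an amide-type nitrogen. Two readable steps involve the 3-carbamoylphenyl group: an at least 8.0-fold lower number from compound 1 to compound 2 (0.90 log units; beyond the scatter), and an at least 8.0-fold higher number from compound 2 to compound 3 (0.90 log units; beyond the scatter). The third, a step that the two limits leave unreadable from compound 1 to compound 3, compares two limits. Compound 4 lacks the 3-carbamoylphenyl group, so no large fall is expected, and the estimated change is an at least 1.3-fold lower number from compound 3 to compound 4 (0.12 log units; that floor lies within the scatter). Compound 4 is estimated at 150000 nM, within an expected range of 50000 nM to 200000 nM.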

Compound 4, half-maximal cytotoxic concentration: 75000 nM
Compound 4: the middle estimate sits 2.0-fold (0.30 log units) above what was measured, and the stated range covers the measured number.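

Even without the 3-carbamoylphenyl group, the number falls in this assay: 2,3-difluorophenyl gives an at least 2.6-fold lower number from compound 3 to compound 4 (0.42 log units; beyond the scatter), and an at least 2.6-fold lower number from compound 1 to compound 4 (0.42 log units; beyond the scatter). This ring is still better tolerated than 3-carbamoylphenyl, with a 3.0-fold higher number from compound 2 to compound 4 (0.48 log units; beyond the scatter). Fluorine-bearing rings at this position therefore do not all behave alike, and the amide ring can shift the number by a moderate amount as well as a large one.

Going by these compounds, whether an amine or a carboxylic acid on this ring would lower the number further remains open. The full size of the steps from compound 1 and compound 3 also remains open because both compounds give only a limit: the limit of > 200000 nM in this assay, at which 2 of the 4 values shown sit.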